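The compounds below may be only part of what the source reports. "The series", "measured", "known", "first", "only" and "open" are said of these compounds alone.

Of the compounds shown here, three have been measured so far in a functional assay on M12 cells (Homo sapiens) for antiproliferative activity, read by WST assay, with a stated time of 72 h (a higher number here means that more compound is needed for the effect, a lower number that less compound is needed), and they give a first picture. Compound 1 (`CCCCCCCC/C=C\c1c(C)cc(C)nc1CCCOC`) gives 31.7 uM there, compound 2 (`CCCCCCCC/C=C\c1c(C)c(/C=C\CCCCCCCC)c2[n+](c1C)CCC2`) gives 3.3 uM and compound 3 (`CCCCCCCCCCc1c(C)cc2[n+](c1C)CCC2`) gives 1.7 uM in the same test. Compound 2 therefore stands close to compound 3, with the two values lying within the usual scatter of each other, while compound 1 needs clearly more compound, a gap well beyond that scatter.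

Compound 4 (`CCCCCCCC/C=C\c1c(C)cc(C)[n+]2c1CCC2`) has not been measured yet. Going to it from compound 2, the structure changes as follows: hydrogen in place of dec-1-en-1-yl on an aromatic carbon. One long chain goes and one stays. Compound 3 also carries one long chain and gives 1.7 uM here, so no step beyond the scatter is expected in this assay for this change. The estimated step of a 1.3-fold lower number from compound 2 to compound 4 (0.12 log units; within the scatter) is therefore small. For compound 4 the expected value is 2.5 uM with 0.8 uM to 8 uM as the estimated range.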

Compound 4, concentration for half-maximal effect: 1.3 uM
Estimate against measurement, compound 4: 1.9-fold (0.28 log units) above; low and high end bracket the measured number.
By their numbers in this assay, from the lowest: compounds 4, 3 and 2 (each within the scatter of the next, the first and the last beyond it); then compound 1.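

In this assay, putting hydrogen in place of dec-1-en-1-yl on the aromatic carbon ortho to two methyl groups gives a 2.5-fold lower number from compound 2 to compound 4 (0.40 log units; beyond the scatter), a modest step. For the compounds shown here, this is the first comparison here between measured compounds that differ in one place, and it shows that this position needs no long chain for the antiproliferative effect: with 10 heavy atoms gone, less compound is needed, not more. Nothing available explains this gain.

As far as these compounds go, only the two extremes are known at this position, so it remains open how a short chain such as ethyl, or a group such as an amine or a carboxylic acid, would behave there. From the compounds shown here alone, it is also open how far the remaining dec-1-en-1-yl chain could be shortened, for example to a hexyl chain, with the number staying this low.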